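The source may report more compounds than this note shows. Statements on the series, on what has been measured and on what is new or still open speak of the compounds shown alone.

Compound 2 `C[C@H](NC(=O)c1ccc(C#Cc2cccc(F)c2)cn1)C(C)(C)C` and compound 1 `Cc1cc(C(=O)N[C@H](C)C(C)(C)O)ncc1C#Cc1cccc(F)c1` share the same core and differ only in the group on the amide nitrogen. In a functional assay on HEK293 cells for positive allosteric modulation of metabotropic glutamate receptor 5 (Rattus norvegicus), read by fluorescence and calcium flux (on this read-out higher numbers stand for larger maximal responses and lower numbers for smaller maximal responses), compound 2 gives 70.8%, the higher of the two numbers seen so far; in this assay compound 1 gives 66.6%, and the gap between the two is within the scatter, so no order can be read from it. Compound 3 `CC(C)(O)CCNC(=O)c1ccc(C#Cc2cccc(F)c2)cn1` has not yet been measured. It differs from compound 2 in one place: 3-hydroxy-3-methylbutyl in place of 1,2,2-trimethylpropyl on an amide-type nitrogen. Within the data shown here, no measured pair shows exactly this change, but compound 1 already carries a chain with a hydroxy group on the amide nitrogen and gives 66.6%, close to compound 2. The step of a number 2.8 percentage points lower from compound 2 to compound 3 (within the scatter) is therefore expected to be small, with no direction beyond the scatter. Compound 3 is estimated to give 68%, with a range from 52% to 84%.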

Compound 3, largest response reached (reported as efficacy), in percent of the reference or control that the assay uses: 61.9%
The estimate for compound 3 lay 6.1 percentage points above the measured number, within the range that was stated.
By their numbers in this assay, from the lowest: compounds 3, 1 and 2 (each within the scatter of the next).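

In this assay, putting 3-hydroxy-3-methylbutyl in place of 1,2,2-trimethylpropyl on the amide-type nitrogen gives a number 8.9 percentage points lower from compound 2 to compound 3 (within the scatter). Among these compounds, this is the first direct reading of this change on the shared core: this position accepts a chain carrying a hydroxy group, with its added hydrogen-bond donor and acceptor and without the defined stereocentre, with no step beyond the scatter. Nothing measured here offers an explanation for the size of this step.

The change from compound 2 to compound 3 alters the hydroxy group, the chain shape and the stereocentre together, so this one pair cannot separate their contributions. It also remains open whether an amine, a carboxylic acid or a longer chain on this nitrogen would stay within the scatter of these compounds.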